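Replacing One Bromo Group in Compound 1 with Hydrogen

The compounds below may be only part of what the source reports. "The series", "measured", "known", "first", "only" and "open" are said of these compounds alone.

- Compound 1 `O=c1nc2ccc(Br)cn2cc1Cc1ccc(Br)cc1`: 102000 nM
- Compound 2 `Nc1cccn2cc(Cc3ccc(F)cc3)c(=O)nc12`: > 1000000 nM

Going by the values given here, in a functional assay on A549 cells (Homo sapiens) for cytotoxicity, read by MTT assay, with a stated time of 24 h (on this read-out lower numbers stand for stronger inhibition and higher numbers for weaker inhibition), compound 1 gives 102000 nM, the only exact number so far. Compound 2 is reported only as a limit, > 1000000 nM. Compound 1 therefore cannot be placed in a series, and the distance between the two compounds cannot be stated.

Compound 3 `O=c1nc2ccc(Br)cn2cc1Cc1ccccc1` has not yet been measured in this assay. It carries hydrogen in place of bromo on an aromatic carbon of a six-membered aromatic ring of carbon only, para to a large group: hydrogen in place of bromo on an aromatic carbon. Among the compounds with values here, no measured pair of compounds differs in only one place, so the expectation is loose. A modest loss of inhibition is expected, slightly beyond the usual scatter, with a 1.8-fold higher number from compound 1 to compound 3 (0.25 log units; within the scatter) as the estimated step. For compound 3, the estimated value is 180000 nM, within an expected range of 70000 nM to 500000 nM.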

Compound 3, half-maximal inhibitory concentration: > 1000000 nM
Compound 3 ended at the assay's limit (the forecaster's own chance of this, stated with the estimate: 15%); middle value at least 5.5-fold (0.74 log units) from the limit.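

In this assay, taking the bromo off the six-membered aromatic ring of carbon only, para to a large group, gives an at least 9.8-fold higher number from compound 1 to compound 3 (0.99 log units; beyond the scatter). Going by these compounds alone, this is the first step that can be read, and it shows that the measurable inhibition of compound 1 is lost without this bromo. Compound 3 stands at > 1000000 nM, which is a limit of the assay and not a number, so the step gives only the smallest size the change can have, and compound 3 shares that ceiling with another compound: the limit of > 1000000 nM in this assay, at which 2 of the 3 values shown sit.

From the compounds shown here alone, whether a chloro, a methyl or a methoxy group at this place would keep the inhibition of compound 1 remains open. So does the contribution of the other bromo, on the shared core, which stays in place in compound 3.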